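The source may hold more compounds than are shown below. What is called first, only, known or untested is meant among the compounds shown, and "the series" means these compounds.

Measured in a functional assay on SMMC-7721 cells (Homo sapiens) for antiproliferative activity, read by MTT assay, with a stated time of 72 h (a lower number here means a stronger inhibitor, a higher number a weaker inhibitor), every value a limit:
compound 1 `C#CCSc1nc(Sc2nc(C)c(C)s2)c(C#N)c(-c2cc(OC)c(OC)c(OC)c2)n1`: > 20000 nM
compound 2 `C#CCSc1nc(Sc2ccccn2)c(C#N)c(-c2cc(OC)c(OC)c(OC)c2)n1`: > 20000 nM
compound 3 `C#CCSc1nc(Sc2nc[nH]n2)c(C#N)c(-c2cc(OC)c(OC)c(OC)c2)n1`: > 20000 nM

Compound 3 gives no number and sits at the limit of > 20000 nM in this assay, at which 3 of the 3 values shown sit. Compound 4 `C#CCSc1nc(Sc2nc3ccccc3s2)c(C#N)c(-c2cc(OC)c(OC)c(OC)c2)n1` carries 1,3-benzothiazol-2-yl in place of 1H-1,2,4-triazol-3-yl on the sulfur: 1,3-benzothiazol-2-yl in place of 1H-1,2,4-triazol-3-yl on a sulfur. The measured exchanges on that sulfur give no size to carry over: a step that the two limits leave unreadable from compound 1 to compound 2, a step that the two limits leave unreadable from compound 1 to compound 3 and a step that the two limits leave unreadable from compound 2 to compound 3. Going by the values given here, no step of definite size or direction can therefore be derived from them, and compound 4 is expected to stay near the same limit in this assay. The expected change is a number no higher from compound 3 to compound 4 (the limit leaves the size open). For compound 4 the estimate is 20000 nM, with an expected range of 8000 nM to 40000 nM.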

Compound 4, half-maximal inhibitory concentration: > 20000 nM
Compound 4: no number, only a limit (the forecaster's own chance of this, stated with the estimate: 70%); the middle value lies on the limit itself.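

In this assay, going by these compounds alone, compound 4 gives only a limit, > 20000 nM, so no step to compound 4 from compound 1, compound 2 or compound 3 can be read: the limit of > 20000 nM in this assay, at which 4 of the 4 values shown sit. The compounds shown leave open whether any group on this sulfur gives a measurable value.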